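The compounds below may be only part of what the source reports. "The series", "measured", "known", "first", "only" and "open" are said of these compounds alone.

Compound 2 `COc1ccccc1OS(=O)(=O)C1CC2OC1C(c1ccc(NC(=O)CCCCCCC(=O)NO)cc1)=C2c1ccc(O)cc1` sits near the upper end of the numbers seen so far: in a functional assay on MCF7 cells (Homo sapiens) for inhibition, read by MTT assay, with a stated time of 72 h (on this read-out lower numbers stand for stronger inhibition and higher numbers for weaker inhibition), compound 2 gives 25800 nM. Compound 1 `O=C(O)CCCCCCC(=O)Nc1ccc(C2=C(c3ccc(O)cc3)C3CC(S(=O)(=O)Oc4ccccc4C(F)(F)F)C2O3)cc1` gives 26100 nM, which lies within the scatter of the number for compound 2, so no order between them can be claimed. For the measured compounds named here, compound 3 `Cc1ccccc1OS(=O)(=O)C1CC2OC1C(c1ccc(NC(=O)CCCCCCC(=O)O)cc1)=C2c1ccc(O)cc1` gives 7900 nM, and the step of a 3.3-fold lower number from compound 1 to compound 3 (0.52 log units; beyond the scatter) is the only change at the aryl sulfonate that has been measured; it shows that the group on that oxygen does move the number by a modest amount.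

Compound 4 `O=C(CCCCCCC(=O)Nc1ccc(C2=C(c3ccc(O)cc3)C3CC(S(=O)(=O)Oc4cccc5ccccc45)C2O3)cc1)NO` differs from compound 2 by one change: naphthalen-1-yl in place of 2-methoxyphenyl on an oxygen. Going by the values given here, no measured pair swaps a methoxy-bearing ring for a two-ring aromatic at this oxygen, so the only guide is that a change here once gave a modest shift. A step of similar size in either direction, or none beyond the scatter, is therefore expected; the central expectation is a step of a 1.7-fold lower number from compound 2 to compound 4 (0.24 log units; within the scatter). For compound 4 the expected value is 15000 nM, with a range from 4000 nM to 50000 nM.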

Compound 4, half-maximal inhibitory concentration: 13400 nM
For compound 4 the middle estimate is 1.1-fold (0.05 log units) above the measured one, within the range that was stated.
By their numbers in this assay, from the lowest: compounds 3, 4, 2 and 1 (each within the scatter of the next, the first and the last beyond it).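

In this assay, the step of a 1.9-fold lower number from compound 2 to compound 4 (0.28 log units; within the scatter) shows that this oxygen can carry naphthalen-1-yl, with its two aromatic rings and no methoxy oxygen, without a readable change from 2-methoxyphenyl. The earlier step at this oxygen was measured with a carboxylic acid at the end of the chain and went beyond the scatter, whereas this one, measured with a hydroxamic acid there, stays within it. So a change at this oxygen need not shift the number, even when it swaps one aromatic ring for two. No measurement on hand explains this result.

As far as these compounds go, whether a plain phenyl or a pyridin-3-yl at this oxygen would stay within the scatter of compound 2 remains open. So does whether naphthalen-1-yl would behave the same way with a carboxylic acid at the end of the chain.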